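Swapping fluoro for hydrogen on compound 1

This account rests on a few compounds, and the source may have more. Where it says the series, first, only, none or still open, it means among the compounds named here.

Compound 1 `Nc1nc(F)nc2c1ncn2[C@@H]1O[C@H](CO)C=C1F` is tested in an ADME assay on Vero cells (Chlorocebus sabaeus) for cytotoxicity (on this read-out lower numbers stand for stronger inhibition and higher numbers for weaker inhibition), and compound 1 gives > 100000 nM, which is a limit of the assay and not a number. So compound 1 has no exact position on this scale, only a limit.

Its close relative, compound 2 `Nc1nc(F)nc2c1ncn2[C@H]1O[C@H](CO)C=C1F`, gives 16100 nM. The measured step is an at least 6.2-fold lower number from compound 1 to compound 2 (0.79 log units; beyond the scatter). It bears on the present question only indirectly, as it reflects the fact that compounds 1 and 2 differ only in the configuration as drawn and leaves the fluoro group in place.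

Compound 3 `Nc1ncnc2c1ncn2[C@@H]1O[C@H](CO)C=C1F` keeps the drawn configuration of compound 1 but carries hydrogen in place of fluoro on an aromatic carbon, between two ring nitrogen atoms: hydrogen in place of fluoro on an aromatic carbon. For the measured compounds named here, no measured step shows what this swap does, so the size of the step from compound 2 cannot simply be carried over. The starting point remains compound 1 at > 100000 nM, and no step beyond the scatter is expected in this assay.

The estimated change is a number no higher from compound 1 to compound 3 (the limit leaves the size open).

For compound 3 the expected value is 100000 nM, with an estimated range from 35000 nM to 300000 nM.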

Compound 3, half-maximal inhibitory concentration: > 100000 nM
Compound 3 gave a limit, no number; the forecaster's own chance of this, stated with the estimate: 65%; the middle value sits exactly at the limit.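

In this assay, for the compounds shown here, compound 3 gives > 100000 nM, which is a limit of the assay and not a number, just as compound 1 gives a limit, so no step between the two can be read. The compounds shown leave open whether hydrogen in place of fluoro on an aromatic carbon changes this read-out at all.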